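Free fraction after leaving the 4-(fluoromethyl)cyclohexyl group

The compounds below may be only part of what the source reports. "The series", "measured", "known", "first", "only" and "open" are said of these compounds alone.

Measured in an ADME assay for protein binding, using equilibrium dialysis, at pH 7.4, tested at 2 uM (on this read-out higher numbers stand for a larger free fraction and lower numbers for a smaller free fraction), so far:
compound 1 `CC(C)N(c1cc(C#CC(C)(C)C)sc1C(=O)O)C(=O)[C@H]1CC[C@H](C)CC1` gives 0.06
compound 2 `CC(C)N(c1cc(C#CC(C)(C)C)sc1C(=O)O)C(=O)[C@H]1CC[C@H](CF)CC1` gives 0.18

Of these two, compound 2 stands highest at 0.18 in this assay and clear of the other. The next step leads to compound 3 `CC(C)N(C(=O)[C@H]1[C@@H]2CCCC[C@@H]21)c1cc(C#CC(C)(C)C)sc1C(=O)O` and is a group of 7 heavy atoms (7 carbon; one three-membered non-aromatic ring of carbon only, one six-membered non-aromatic ring of carbon only) in place of a group of 8 heavy atoms (7 carbon, 1 fluorine; one six-membered non-aromatic ring of carbon only), on a carbonyl carbon on a carbonyl carbon whose other neighbours are: amide-type nitrogen. For the measured compounds named here, the one measured step bearing on this is a 3.0-fold higher number from compound 1 to compound 2 (0.48 log units; beyond the scatter) and it is modest but beyond the scatter, with fluoro in place of hydrogen on a saturated chain carbon. Compound 3 carries no fluorine, and neither does compound 1, so a number nearer to that of compound 1 is expected. The expected change in this assay is a modest fall, an estimated 2.0-fold lower number from compound 2 to compound 3 (0.30 log units; within the scatter) in size. The estimated value for compound 3 is 0.09 (expected range 0.04 to 0.2).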

Compound 3, unbound fraction: 0.04
Compound 3: middle estimate off by 2.3-fold (0.35 log units), on the high side; measured number inside the range.
By their numbers in this assay, from the lowest: compounds 3 and 1 (each within the scatter of the next); then compound 2.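

In this assay, replacing the 4-(fluoromethyl)cyclohexyl group on the carbonyl carbon with the fluorine-free group carrying one three-membered and one six-membered carbon ring gives a 4.5-fold lower number from compound 2 to compound 3 (0.65 log units; beyond the scatter), so the higher number of compound 2 does not survive this change. Between the two fluorine-free groups the step is a 1.5-fold lower number from compound 1 to compound 3 (0.18 log units; within the scatter), and among the three compounds only compound 2, the one fluorine-bearing compound, stands clear of the others. No evidence is at hand on what lies behind these steps.

As far as these compounds go, whether a difluoromethyl or a hydroxymethyl group in place of the fluoromethyl would keep or extend the higher number stays open. Also open, from the compounds shown here alone, is whether a fluorine added to the group of compound 3 would give a step of the size of a 3.0-fold higher number from compound 1 to compound 2 (0.48 log units; beyond the scatter).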